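A few compounds are considered here, and "the series" means these few. Any claim that something is new, unique, unknown or untested is made for them only; others in the source may bear on it.

Compound 1, `COC(=O)C1=C(C)NC(=O)N(C(=O)NCCCN2CCN(c3ccccc3OC)CC2)C1c1ccc(F)c(F)c1`: 18 nM in an assay on liver for binding affinity to Alpha-1B adrenergic receptor (Homo sapiens), using microsomes; on this read-out higher numbers stand for weaker inhibition and lower numbers for stronger inhibition. Compound 2, `COC(=O)C1=C(C)NC(=O)N(C(=O)NCCCN2CCN(c3ccccc3O)CC2)C1c1ccc(F)c(F)c1`: 16 nM.

Compound 2 stands next to compound 1, the two within the usual scatter of each other. Compound 3, `COC(=O)C1=C(C)NC(=O)N(C(=O)NCCCN2CCN(c3ccc(OC)cc3C)CC2)C1c1ccc(F)c(F)c1`, differs from compound 2 in one place: 4-methoxy-2-methylphenyl in place of 2-hydroxyphenyl on an amine nitrogen in a ring. Among the measured compounds shown here, the only measured step, a 1.1-fold lower number from compound 1 to compound 2 (0.05 log units; within the scatter), altered a group on the same aromatic ring and stayed within the scatter. For the measured compounds named here, compound 3 exchanges the whole ring, which no measured step covers, so the guide is weak. For compound 3 a small step toward a higher number, a 1.9-fold higher number from compound 2 to compound 3 (0.27 log units; within the scatter), is expected, with an estimated value of 30 nM, between 8 nM and 120 nM.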

Compound 3, inhibition constant: 510 nM
Estimate against measurement, compound 3: 17-fold (1.23 log units) below; measured number outside the range, above it.
By their numbers in this assay, from the lowest: compounds 2 and 1 (each within the scatter of the next); then compound 3.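

Replacing the whole aromatic group on this ring nitrogen matters far more than the small change on its oxygen. Putting in 4-methoxy-2-methylphenyl gives a 32-fold higher number from compound 2 to compound 3 (1.50 log units; beyond the scatter), and measured against the 2-methoxyphenyl compound it gives a 28-fold higher number from compound 1 to compound 3 (1.45 log units; beyond the scatter), so the large rise appears from either starting point. Nothing measured here explains the rise.

Going by these compounds, the 4-methoxy and 2-methyl parts enter together, so their separate shares remain unknown. On these data alone, how a plain phenyl group or a chlorine atom on the ring would fare also remains open.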